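From a furan to an imidazole on the shared core

This account rests on a few compounds, and the source may have more. Where it says the series, first, only, none or still open, it means among the compounds named here.

Of the compounds shown here, three built on one shared core have been tested in a functional assay for activation of Alpha-1D adrenergic receptor (Homo sapiens), read by calcium flux; a lower number here means that less compound is needed, a higher number that more compound is needed for the effect. Compound 1 `Cc1ccnc(-c2ccccc2OCC2=NCCN2)c1` gives < 100000 nM, which is a limit of the assay and not a number. Compound 2 `Cc1cccc(-c2ccccc2OCC2=NCCN2)n1` gives < 100000 nM, again a limit. Compound 3 `c1coc(-c2ccccc2OCC2=NCCN2)c1` gives < 100000 nM, also a limit. Where compound 3 stands among the numbers shown is therefore only as one of the three values that sit at the limit of < 100000 nM in this assay, at which 3 of the 3 values shown sit; no order among compounds 1, 2 and 3 can be read from these values, and no measured step between any two of them is known.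

Compound 4 `c1ccc(-c2ncc[nH]2)c(OCC2=NCCN2)c1` has not yet been measured in this assay. It differs from compound 3 by 1H-imidazol-2-yl in place of furan-2-yl on an aromatic carbon. Going by the values given here, every value so far in this assay is only a limit. Among the compounds with values here, no measured step exists that could set the size or direction of this change. The step is expected to be a step that the limit leaves unreadable from compound 3 to compound 4, an estimate resting on nothing firmer than the limits shown. Compound 4 is expected to give about 10000 nM in this assay, within an estimated range from 300 nM to 100000 nM, with a real chance that the assay once more reports only a limit.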

Compound 4, half-maximal effective concentration: < 100000 nM
Compound 4: a limit, no number; the forecaster's own chance of this, stated with the estimate: 65%; the middle value lies beyond the limit too.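

In this assay compound 4 gives < 100000 nM, which is a limit of the assay and not a number. Compound 3 also stands at a limit, so no step between compound 3 and compound 4 can be read: the limit of < 100000 nM in this assay, at which 4 of the 4 values shown sit.

The compounds shown leave open how 1H-imidazol-2-yl in place of furan-2-yl alters the result in this assay, and how compounds 1 to 4 rank.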